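The source may hold more compounds than are shown below. What is called first, only, known or untested is meant among the compounds shown, and "the series" means these compounds.

Series notes. Compound 1 `O=C1Oc2ccccc2N/C1=C\C(=O)c1cccs1` in an ADME assay on Vero cells (Chlorocebus sabaeus) for cytotoxicity, read by MTT assay, with a stated time of 72 h (on this read-out lower numbers stand for higher toxicity in this test and higher numbers for lower toxicity in this test), gives only a limit of the assay, > 1840000 nM. Compound 2 `COC(=O)/C=C1/Oc2ccccc2NC1=O` has no result in this assay, "not determined" (no result reported). Compound 3 `O=C1Oc2ccccc2N/C1=C\C(=O)c1ccncc1` likewise gives only a limit in this assay, > 1870000 nM. The step from compound 1 to compound 3 is a step that the two limits leave unreadable from compound 1 to compound 3, which follows because both values sit at limits (the limit of > 1840000 nM in this assay, at which 1 of the 3 values shown sits, and (the limit of > 1870000 nM in this assay, at which 1 of the 3 values shown sits)). Compound 3 therefore stands at a limit, with one further limit and one entry without a number beside it. Compound 4 `Cc1ccccc1C(=O)/C=C1\Nc2ccccc2OC1=O` differs from compound 3 by 2-methylphenyl in place of pyridin-4-yl on a carbonyl carbon. Only the unreadable step bears on this change, so no direction beyond the scatter can be expected, and compound 4 is expected to return a limit again. The expected step from compound 3 to compound 4 is a number no higher from compound 3 to compound 4 (the limit leaves the size open). For compound 4 the estimate is 1850000 nM, within 500000 nM to 6000000 nM.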

Compound 4, half-maximal cytotoxic concentration: > 1790000 nM
Compound 4 gave a limit, no number (the forecaster's own chance of this, stated with the estimate: 80%); the middle value does not contradict the limit.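

The steps among compound 1, compound 3 and compound 4 cannot be read, as all three values are limits of the assay. The compounds shown leave open whether the group on the carbonyl carbon changes the read-out in this assay at all.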